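Anilide series on the shared core: chloro on the anilino ring

The compounds below may be only part of what the source reports. "The series", "measured", "known", "first", "only" and "open" are said of these compounds alone.

Measured in a functional assay on PC-3 cells (Homo sapiens) for inhibition, read by MTT assay, with a stated time of 72 h; on this read-out lower numbers stand for stronger inhibition and higher numbers for weaker inhibition:
- compound 1 `O=C(CSc1nc(Nc2ccccc2)c2ccccc2n1)Nc1cccc([N+](=O)[O-])c1` gives 11800 nM
- compound 2 `CCc1cccc(NC(=O)CSc2nc(Nc3ccccc3)c3ccccc3n2)c1` gives 11000 nM
- compound 3 `C=CC(=O)Nc1cccc(NC(=O)CSc2nc(Nc3ccccc3)c3ccccc3n2)c1` gives 8740 nM

Compound 3 sits at the low end of the three numbers, yet the steps of a 1.4-fold lower number from compound 1 to compound 3 (0.13 log units; within the scatter) and a 1.3-fold lower number from compound 2 to compound 3 (0.10 log units; within the scatter) both lie within the scatter, as does a 1.1-fold lower number from compound 1 to compound 2 (0.03 log units; within the scatter), so the three compounds cannot be told apart on this read-out. All three measured changes sit on the anilide ring that carries the nitro, ethyl or (vinylcarbonyl)amino group.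

Compound 4 `C=CC(=O)Nc1cccc(NC(=O)CSc2nc(Nc3cccc(Cl)c3)c3ccccc3n2)c1` differs from compound 3 at the other end of the core: chloro in place of hydrogen on an aromatic carbon, meta to a large group, so that the anilino becomes (3-chlorophenyl)amino. For the measured compounds named here, no measured step touches this ring, so nothing directly bears on the change. Going by the values given here, the only guide is that every change so far, on the other ring, stayed within the scatter; a shift beyond the scatter is therefore not expected in this assay, in either direction.

Compound 4 is expected to give about 8000 nM, in a range from 3000 nM to 20000 nM, which means a step of a 1.1-fold lower number from compound 3 to compound 4 (0.04 log units; within the scatter) that is expected to stay within the scatter.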

Compound 4, half-maximal inhibitory concentration: 12300 nM
Beside the measured number, compound 4's estimate is 1.5-fold (0.19 log units) below it; low and high end bracket the measured number.
By their numbers in this assay, from the lowest: compounds 3, 2, 1 and 4 (each within the scatter of the next).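

In this assay, for the compounds shown here, the only step on the anilino ring reads a 1.4-fold higher number from compound 3 to compound 4 (0.15 log units; within the scatter) so chloro in place of hydrogen, meta to a large group, does not separate compound 4 from compound 3 on this read-out. The earlier steps shown here all lay on the anilide ring, and this one adds that a change at the other end of the shared core, with this group at this position, also produces no shift beyond the scatter. No measurement shown here bears on why the step has this size, and no explanation of it can be offered.

A single chloro at a single position cannot show whether this ring stays as flat in the read-out as the anilide ring has so far. From the compounds shown here alone, whether a methoxy group, an amine, a carboxylic acid or a longer chain on the anilino ring would move the number beyond the scatter, in either direction, remains open, as does whether chloro would behave the same way at another position on that ring.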